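Cyclopropylamino Replaces Hydroxy on the Benzylic Carbon

The source may hold more compounds than are shown below. What is called first, only, known or untested is meant among the compounds shown, and "the series" means these compounds.

Measured compounds:
compound 1 `Cn1nc2c(=O)n(CC3(O)CCN(Cc4ccc(-c5ccco5)cc4Cl)CC3)cnc2c1-c1ccc(CNC(=O)C(F)(F)F)cc1` — 2060 nM
compound 2 `Cn1nc2c(=O)n(CC3(O)CCN(Cc4ccc(-c5ccco5)cc4Cl)CC3)cnc2c1-c1ccc(Cl)cc1` — 143 nM
compound 3 `Cn1nc2c(=O)n(CC3(O)CCN(Cc4ccc(-c5ccco5)cc4Cl)CC3)cnc2c1-c1ccc(CO)cc1` — 42.5 nM

In an assay on isolated protein for inhibition of ubiquitin carboxyl-terminal hydrolase 7 (Homo sapiens), with stated times of 30 min and 2 h (a higher number here means a weaker inhibitor, a lower number a stronger inhibitor), compound 3 gives the lowest number of the three, with compound 2 the nearest and compound 1 the furthest away. The step under consideration leads from compound 3 to compound 4 `Cn1nc2c(=O)n(CC3(O)CCN(Cc4ccc(-c5ccco5)cc4Cl)CC3)cnc2c1-c1ccc(CNC2CC2)cc1`, and the change is cyclopropylamino in place of hydroxy on a saturated chain carbon bound to an aromatic carbon. The measured step that bears most directly on it is the one at the same saturated chain carbon, a 48-fold lower number from compound 1 to compound 3 (1.69 log units; beyond the scatter), which was large: there a larger group on that carbon went with a much higher number than hydroxy. The other two steps, a 14-fold lower number from compound 1 to compound 2 (1.16 log units; beyond the scatter) and a 3.4-fold lower number from compound 2 to compound 3 (0.53 log units; beyond the scatter), concern the aromatic carbon itself rather than the chain carbon, and they show the same ordering, hydroxymethyl lowest and the largest substituent highest. Compound 4 carries a group between those two in size, so a number somewhat above that of compound 3 is expected, a step of a 2.8-fold higher number from compound 3 to compound 4 (0.45 log units; beyond the scatter), smaller than the step from compound 1 to compound 3 yet beyond the scatter. Compound 4 is therefore estimated at 120 nM, with a range from 35 nM to 400 nM.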

Compound 4, half-maximal inhibitory concentration: 54.1 nM
Beside the measured number, compound 4's estimate is 2.2-fold (0.35 log units) above it; the measured number falls inside the stated range.
By their numbers in this assay, from the lowest: compounds 3 and 4 (each within the scatter of the next); then compound 2; then compound 1.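

In this assay, cyclopropylamino, with its 4 heavy atoms and three-membered ring, takes the place of the single oxygen of hydroxy on the saturated chain carbon bound to an aromatic carbon in a step of a 1.3-fold higher number from compound 3 to compound 4 (0.10 log units; within the scatter) and so leaves the two compounds within the scatter of each other. The high number of compound 1 therefore does not follow from a larger group on this carbon alone: on the same amine nitrogen, cyclopropyl in place of (trifluoromethyl)carbonyl gives a 38-fold lower number from compound 1 to compound 4 (1.58 log units; beyond the scatter) and a large step in this series. The replacement of chloro by (cyclopropylamino)methyl gives a 2.6-fold lower number from compound 2 to compound 4 (0.42 log units; beyond the scatter) as a modest step, so compound 4, like compound 3, stands clear of compound 2 by more than the scatter.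

No measurement shown here accounts for any of these steps. On these data alone, it remains open whether a plain primary amine, a dimethylamino group, a morpholine or a carboxylic acid on this carbon would keep the number in the range of compound 3 and compound 4, and whether a larger ring on the nitrogen, such as cyclohexyl, would do the same.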